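A phenyl swap on compound 2

This account rests on a few compounds, and the source may have more. Where it says the series, first, only, none or still open, it means among the compounds named here.

Compound 1 `CN(c1cccc2c1CN(c1nc(Nc3ccc(C(F)(F)F)cc3)ncc1C(F)(F)F)C2)S(C)(=O)=O` gives > 30000 nM as a limit, not a number
Compound 2 `Cc1cc(Cl)ccc1Nc1ncc(C(F)(F)F)c(N2Cc3cccc(N(C)S(C)(=O)=O)c3C2)n1` gives 19600 nM

For the measured compounds named here, in a functional assay on HepG2 cells (Homo sapiens) for antiproliferative activity, read by spectrophotometry, with a stated time of 2 days (on this read-out higher numbers stand for weaker inhibition of growth and lower numbers for stronger inhibition of growth), compound 2 gives 19600 nM as the only exact number so far. Compound 3 `CN(c1cccc2c1CN(c1nc(Nc3cccc(C(F)(F)F)c3)ncc1C(F)(F)F)C2)S(C)(=O)=O` differs from compound 2 by 3-(trifluoromethyl)phenyl in place of 4-chloro-2-methylphenyl on a nitrogen on an aromatic ring on the same nitrogen. Going by the values given here, the one measured step, an at least 1.5-fold lower number from compound 1 to compound 2 (0.18 log units; that floor lies within the scatter), exchanged 4-(trifluoromethyl)phenyl for 4-chloro-2-methylphenyl, and its floor lies within the scatter. No change beyond the scatter is therefore expected, and the expected step is small (a 1.3-fold higher number from compound 2 to compound 3 (0.11 log units; within the scatter)). For compound 3 the estimated value is 25000 nM (expected range 11000 nM to 50000 nM).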

Compound 3, concentration for 50% growth inhibition: > 30000 nM
Compound 3: no number, only a limit (the forecaster's own chance of this, stated with the estimate: 40%); middle value at least 1.2-fold (0.07 log units) from the limit.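

In this assay, on these data alone, 3-(trifluoromethyl)phenyl in place of 4-chloro-2-methylphenyl on this nitrogen gives an at least 1.5-fold higher number from compound 2 to compound 3 (0.18 log units; that floor lies within the scatter), so the true size of this change stays unknown. Compound 3 gives a limit, not a number, so moving the trifluoromethyl group around the phenyl ring has not yet yielded an exact value. The step between compound 1 and compound 3 cannot be read because both values are limits: the limit of > 30000 nM in this assay, at which 2 of the 3 values shown sit.

As far as these compounds go, it remains open whether a pyridyl ring on this nitrogen, or an amine or carboxylic acid on the phenyl ring, would give a number clearly lower than that of compound 2.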